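This account rests on a few compounds, and the source may have more. Where it says the series, first, only, none or still open, it means among the compounds named here.

Compound 2 `NC(=O)c1c(NC(=O)c2ccccc2F)sc2c1CCN(C(=S)Nc1ccccc1Cl)C2` gives 12500 nM in a functional assay on HL-60 cells (Homo sapiens) for antiproliferative activity, with a stated time of 24 h; a lower number here means a stronger inhibitor, a higher number a weaker inhibitor. Within the data shown here, it is one of only two compounds measured; the other, compound 1 `NC(=O)c1c(NC(=O)c2ccccc2)sc2c1CCN(C(=S)Nc1ccccc1Cl)C2`, gives 13800 nM in this assay, and the two numbers sit within the scatter of each other, so neither stands apart. Among the measured compounds shown here, the single measured step, a 1.1-fold lower number from compound 1 to compound 2 (0.04 log units; within the scatter), was fluoro in place of hydrogen on an aromatic carbon, and it did not move the number beyond the scatter. Compound 3 `NC(=O)c1c(NC(=O)c2ccccc2Br)sc2c1CCN(C(=S)Nc1ccccc1Cl)C2` differs from compound 2 by bromo in place of fluoro on an aromatic carbon. For the measured compounds named here, that exchange of one halogen for another has not been measured; the one measured step only bears on it indirectly, by showing that the first halogen at that carbon left the number unchanged. On that basis no step beyond the scatter is expected, written as no change at the digits printed from compound 2 to compound 3 (within the scatter), and compound 3 is estimated at 12500 nM, with a range from 5000 nM to 30000 nM.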

Compound 3, half-maximal inhibitory concentration: 14600 nM
Estimate against measurement, compound 3: 1.2-fold (0.07 log units) below; measured number inside the range.
By their numbers in this assay, from the lowest: compounds 2, 1 and 3 (each within the scatter of the next).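

In this assay, the exchange of one halogen for another at this aromatic carbon, ortho to a large group, gives a 1.2-fold higher number from compound 2 to compound 3 (0.07 log units; within the scatter), and bromo in place of hydrogen at the same carbon gives a 1.1-fold higher number from compound 1 to compound 3 (0.02 log units; within the scatter). Together with the earlier fluoro step, these show that hydrogen, fluoro and bromo at this carbon cannot be told apart in this assay, so the lack of a measurable step is not confined to fluoro but also holds for a second halogen. Nothing available explains this result.

The compounds shown leave open whether a group other than a halogen at this carbon, such as an amine, a carboxylic acid or a methoxy group, would give a step beyond the scatter. They also leave open whether bromo at another carbon of this six-membered aromatic ring, or a change elsewhere on the shared core, would do so.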